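Dichlorophenyl Moved to the Sulfonyl Side of a Hydrazide

The compounds below may be only part of what the source reports. "The series", "measured", "known", "first", "only" and "open" are said of these compounds alone.

Compound 1 `CC(=O)Nc1ccc(S(=O)(=O)NNC(=O)c2cccnc2Nc2ccc(Cl)cc2)cc1` was tested in a functional assay on CAKI-1 cells (Homo sapiens) for antiproliferative activity (on this read-out higher numbers stand for lower toxicity in this test and lower numbers for higher toxicity in this test), where compound 1 returned only a limit of the assay, > 100000 nM. Compound 2 `O=C(NNS(=O)(=O)c1ccc(F)cc1)c1cccnc1Nc1ccc(Cl)cc1Cl` was tested in this assay too, and compound 2 likewise returned only a limit, > 100000 nM. For the measured compounds named here, compound 1 therefore stands level with the only other value shown, both at the limit of > 100000 nM in this assay, at which 2 of the 2 values shown sit. Compound 3 `O=C(NNS(=O)(=O)c1ccc(Cl)cc1Cl)c1cccnc1Nc1ccc(Cl)cc1` carries 2,4-dichlorophenyl in place of 4-acetamidophenyl on a sulfonyl sulfur. Going by the values given here, no measured pair isolates this change, so no shift beyond the scatter is expected, and the expected step of a number no higher from compound 1 to compound 3 (the limit leaves the size open) is estimated as none. Compound 3 is expected to give about 100000 nM in this assay, between 30000 nM and 300000 nM.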

Compound 3, concentration lethal to 50% of the cells: > 100000 nM
Compound 3: only a limit was reported; the forecaster's own chance of this, stated with the estimate: 75%; the middle value lies on the limit itself.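

In this assay compound 3 also gave only a limit, > 100000 nM. For the compounds shown here, no step from compound 1 to compound 3 can be read, since all the values stand at one limit: the limit of > 100000 nM in this assay, at which 3 of the 3 values shown sit. The compounds shown leave open whether 2,4-dichlorophenyl in place of 4-acetamidophenyl changes this read-out at all.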